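One acyl group fewer on compound 2

A few compounds are considered here, and "the series" means these few. Any claim that something is new, unique, unknown or untested is made for them only; others in the source may bear on it.

- compound 1 `CC(C)[C@H](N)C(=O)OC[C@H]1O[C@@H](n2cc(F)c(=O)[nH]c2=O)C[C@@H]1O`: 38100000 nM
- compound 2 `CC(C)[C@H](N)C(=O)OC[C@H]1O[C@@H](n2cc(F)c(=O)[nH]c2=O)C[C@@H]1OC(=O)[C@@H](N)C(C)C`: 31700000 nM

In a functional assay on MDA-MB-231 cells (Homo sapiens) for inhibition, read by MTT assay, with a stated time of 24 h (on this read-out higher numbers stand for weaker inhibition of growth and lower numbers for stronger inhibition of growth), compound 2 gives 31700000 nM, within the scatter of compound 1. Compound 3 `CC(C)[C@H](N)C(=O)O[C@H]1C[C@H](n2cc(F)c(=O)[nH]c2=O)O[C@@H]1CO` differs from compound 2 by hydrogen in place of (1-amino-2-methylpropyl)carbonyl on an oxygen on a saturated carbon, with hydrogen in place of (1-amino-2-methylpropyl)carbonyl on an oxygen on a saturated carbon. Among the compounds with values here, only one measured step bears on this change. It concerns the same group on a different oxygen, and it amounts to a 1.2-fold lower number from compound 1 to compound 2 (0.08 log units; within the scatter). On that evidence, the expected change is a 1.1-fold higher number from compound 2 to compound 3 (0.04 log units; within the scatter), with none anticipated beyond the scatter. The estimate for compound 3 is 35000000 nM, with an expected range of 17000000 nM to 70000000 nM.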

Compound 3, concentration for 50% growth inhibition: 32400000 nM
Estimate against measurement, compound 3: 1.1-fold (0.03 log units) above; the range from low to high includes it.
By their numbers in this assay, from the lowest: compounds 2, 3 and 1 (each within the scatter of the next).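

Taking (1-amino-2-methylpropyl)carbonyl off the oxygen of the hydroxymethyl group gives a 1.0-fold higher number from compound 2 to compound 3 (0.01 log units; within the scatter) in this assay. The earlier step concerned the same group on a different oxygen, so a step within the scatter has now been seen at both oxygens, each time with the group still present on the other. No available measurement explains this result.

The compounds shown leave open how the core reads with hydrogen on both oxygens. They also leave open whether an acetyl group or a longer chain on either oxygen would step beyond the scatter.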